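This account rests on a few compounds, and the source may have more. Where it says the series, first, only, none or still open, it means among the compounds named here.

Measured compounds:
compound 1 `CCCCCCC(O)[C@H](CC(C)C)NC(=O)[C@@H](NC(=O)[C@@H](NC(=O)C(C)C)C(C)C)C(C)C`, 3600 nM
compound 2 `CCCCCCC(O)[C@H](CC(C)C)NC(=O)[C@@H](NC(=O)[C@@H](NC(=O)CC(C)C)C(C)C)C(C)C`, 920 nM
compound 3 `CCCCCCC(O)[C@H](CC(C)C)NC(=O)[C@@H](NC(=O)[C@@H](NC(=O)OC(C)C)C(C)C)C(C)C`, 1200 nM

The three compounds share one core and differ only in the group that caps the chain through a carbonyl. In an assay on isolated protein (plant) for inhibition of Pepsin A (Sus scrofa) (on this read-out higher numbers stand for weaker inhibition and lower numbers for stronger inhibition), compound 2 gives the lowest number of the three. Its nearest neighbour is compound 3: the step of a 1.3-fold higher number from compound 2 to compound 3 (0.12 log units; within the scatter) lies within the scatter, so the two cannot be ranked. Compound 1 stands further away, with a 3.9-fold lower number from compound 1 to compound 2 (0.59 log units; beyond the scatter).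

Compound 4 `CCCCCCC(O)[C@H](CC(C)C)NC(=O)[C@@H](NC(=O)[C@@H](NC(=O)CC)C(C)C)C(C)C` is not yet measured. It differs from compound 2 by methyl in place of isopropyl on a saturated chain carbon bound to a carbonyl carbon. Going by the values given here, only one measured step bears on the size of this cap: a 3.9-fold lower number from compound 1 to compound 2 (0.59 log units; beyond the scatter), where the larger isobutyl gave a lower number than isopropyl. Compound 4 carries an even smaller cap, ethyl, so the expectation is a step back toward or beyond the number of compound 1 in this assay.

Compound 4 is therefore expected to give a higher number, with an estimated step of a 3.0-fold higher number from compound 2 to compound 4 (0.48 log units; beyond the scatter). The estimate for compound 4 is 2800 nM, with a range from 900 nM to 8000 nM.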

Compound 4, half-maximal inhibitory concentration: 3200 nM
Compound 4: middle estimate off by 1.1-fold (0.06 log units), on the low side; low and high end bracket the measured number.
By their numbers in this assay, from the lowest: compounds 2 and 3 (each within the scatter of the next); then compounds 4 and 1 (each within the scatter of the next).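

In this assay, shortening the cap from isobutyl to ethyl gives up what the isobutyl cap had gained: the step of a 3.5-fold higher number from compound 2 to compound 4 (0.54 log units; beyond the scatter) lies beyond the scatter, and the step of a 2.7-fold higher number from compound 3 to compound 4 (0.43 log units; beyond the scatter) also lies beyond it. The step of a 1.1-fold lower number from compound 1 to compound 4 (0.05 log units; within the scatter) lies within the scatter, so the ethyl and isopropyl caps cannot be ranked, and the four compounds form a lower pair, compounds 2 and 3, and a higher pair, compounds 1 and 4. Nothing available explains why the caps divide this way.

As far as these compounds go, whether a longer chain on the carbonyl, such as hexyl, would continue the fall seen with isobutyl remains open. Also open, from the compounds shown here alone, is how a cap bearing an amine, a carboxylic acid or a phenyl ring would read in this assay here.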